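Plasma protein binding: cyclopentyl in place of butyl

A few compounds are considered here, and "the series" means these few. Any claim that something is new, unique, unknown or untested is made for them only; others in the source may bear on it.

Measured compounds:
compound 1 `CCCCN(C)C(=O)OCc1c(C)noc1-c1ccc(O[C@H]2CCC[C@H](C(=O)O)C2)cn1` 0.018
compound 2 `Cc1noc(-c2ccc(O[C@H]3CCC[C@H](C(=O)O)C3)cc2)c1COC(=O)N(C)C1CCCC1` 0.006

In an ADME assay on the whole organism (plasma, Mus musculus, strain CD-1) for protein binding, read by LC-MS, with a stated time of 24 h (a higher number here means a larger unbound share of the compound, a lower number a smaller unbound share), compound 1 gives 0.018, the higher of the two measured values. Compound 2 differs from compound 1 at several places. In this assay compound 2 gives 0.006, a lower number beyond the usual scatter. Compound 3 `Cc1noc(-c2ccc(O[C@H]3CCC[C@H](C(=O)O)C3)cn2)c1COC(=O)N(C)C1CCCC1` is not yet measured. It differs from compound 1 as follows: cyclopentyl in place of butyl on an amide-type nitrogen. For the measured compounds named here, no measured pair shows this change alone. A modest decrease in this assay is expected, so the step of a 1.5-fold lower number from compound 1 to compound 3 (0.18 log units; within the scatter) is estimated to stay within the scatter. Compound 3 is expected to give 0.012, within 0.006 to 0.025.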

Compound 3, unbound fraction: 0.015
Beside the measured number, compound 3's estimate is 1.3-fold (0.10 log units) below it; the range from low to high includes it.
By their numbers in this assay, from the lowest: compound 2; then compounds 3 and 1 (each within the scatter of the next).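

In this assay, cyclopentyl in place of butyl on the amide-type nitrogen, now seen alone, amounts to a 1.2-fold lower number from compound 1 to compound 3 (0.08 log units; within the scatter), so at this place the ring leaves the unbound fraction unchanged within the scatter. Compound 2 also carries cyclopentyl and gives 0.006, while compound 3 gives 0.015, so cyclopentyl alone does not set compound 2 apart. No supporting measurement explains this result. On these data alone, whether a cyclohexyl or a longer chain such as hexyl on this nitrogen would hold the unbound fraction in the same range remains open.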